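A few compounds are considered here, and "the series" means these few. Any claim that something is new, unique, unknown or untested is made for them only; others in the source may bear on it.

In a functional assay on PANC-1 cells (Homo sapiens) for inhibition, read by MTT assay, with a stated time of 24 h (on this read-out lower numbers stand for stronger inhibition and higher numbers for weaker inhibition), compound 1 `CC1(C)[C@H]2CC[C@]1(C)N(Cc1cn(-c3cccc(C#N)c3)nn1)C(=O)C2` gives 260 nM, while compound 2 `CC1(C)[C@H]2CC[C@]1(C)N(Cc1cn(-c3ccc(F)cc3)nn1)C(=O)C2` gives 110 nM, the lower of the two numbers. Going by the values given here, the one measured step, a 2.4-fold lower number from compound 1 to compound 2 (0.37 log units; beyond the scatter), is modest and comes with 4-fluorophenyl in place of 3-cyanophenyl on an aromatic nitrogen. Compound 3 `CC1(C)[C@H]2CC[C@]1(C)N(Cc1cn(-c3ccccc3Cl)nn1)C(=O)C2` keeps the shared core and changes that same group again, with 2-chlorophenyl in place of 4-fluorophenyl on an aromatic nitrogen. Among the compounds with values here, this step offers only a rough guide, since no measured compound carries a chlorine. In this assay, a change no larger than a 2.4-fold lower number from compound 1 to compound 2 (0.37 log units; beyond the scatter) is therefore expected, leaning toward a higher number, as compound 2 already stands lowest at 110 nM. The expected change is a 1.8-fold higher number from compound 2 to compound 3 (0.26 log units; within the scatter). The estimate for compound 3 is 200 nM, with an expected range of 70 nM to 550 nM.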

Compound 3, half-maximal inhibitory concentration: 270 nM
Estimate against measurement, compound 3: 1.4-fold (0.13 log units) below; the range from low to high includes it.
By their numbers in this assay, from the lowest: compound 2; then compounds 1 and 3 (each within the scatter of the next).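

In this assay, a second change at this position on the aromatic nitrogen also moves the number beyond the scatter: swapping 4-fluorophenyl for 2-chlorophenyl gives a 2.5-fold higher number from compound 2 to compound 3 (0.39 log units; beyond the scatter). Set against the 3-cyanophenyl group, the same position gives a 1.0-fold higher number from compound 1 to compound 3 (0.02 log units; within the scatter), so compound 1 and compound 3 cannot be told apart here. Of these three compounds, only compound 2 stands apart from the others, and two differently substituted phenyl groups, 3-cyanophenyl and 2-chlorophenyl, sit at the same level.

No evidence at hand explains these differences. The compounds shown leave open whether the 4-fluorophenyl result depends on fluorine itself or on where it sits, and how an unsubstituted phenyl, or a phenyl bearing an amine or a carboxylic acid, would read out at this position.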